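Compound 3 and a second halogen on its ring

A few compounds are considered here, and "the series" means these few. Any claim that something is new, unique, unknown or untested is made for them only; others in the source may bear on it.

In a functional assay on UACC-62 cells (Homo sapiens) (a higher number here means a weaker inhibitor of growth, a lower number a stronger inhibitor of growth), compound 1 `O=S(=O)(/C=C/c1ccccc1)Cc1ccc(Nc2ncnc3ccccc23)cc1` reads > 100000 nM, which is a limit of the assay and not a number. Compound 2 `N#Cc1ccc(/C=C/S(=O)(=O)Cc2ccc(Nc3ncnc4ccccc34)cc2)cc1` reads > 100000 nM, again a limit. For the measured compounds named here, compound 3 `O=S(=O)(/C=C/c1ccc(Cl)cc1)Cc1ccc(Nc2ncnc3ccccc23)cc1` gives 13000 nM, the only actual number among the three. Compound 4 `O=S(=O)(/C=C/c1ccc(F)cc1Cl)Cc1ccc(Nc2ncnc3ccccc23)cc1` has not yet been measured. It differs from compound 3 by 2-chloro-4-fluorophenyl in place of 4-chlorophenyl on a double-bonded chain carbon bound to a double-bonded chain carbon, with 2-chloro-4-fluorophenyl in place of 4-chlorophenyl on a double-bonded chain carbon bound to a double-bonded chain carbon.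

Going by the values given here, three measured steps bear on this change, all on an aromatic carbon. Chloro in place of hydrogen gave an at least 7.6-fold lower number from compound 1 to compound 3 (0.88 log units; beyond the scatter), and chloro in place of cyano gave an at least 7.6-fold lower number from compound 2 to compound 3 (0.88 log units; beyond the scatter). Cyano in place of hydrogen gave a step that the two limits leave unreadable from compound 1 to compound 2. The evidence is thin, with the limit of > 100000 nM in this assay, at which 2 of the 3 values shown sit. None of these steps involves a fluoro group or the 2-chloro-4-fluorophenyl group.

Compound 4 keeps a chloro group on its ring, and the readable gain of an at least 7.6-fold lower number from compound 1 to compound 3 (0.88 log units; beyond the scatter) came with a chloro group, so no step beyond the scatter is expected in this assay, and neither direction is favoured. The expected step is a 1.2-fold higher number from compound 3 to compound 4 (0.06 log units; within the scatter). For compound 4 the estimate is 15000 nM, with an expected range of 3500 nM to 60000 nM.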

Compound 4, concentration for 50% growth inhibition: 100000 nM
Beside the measured number, compound 4's estimate is 6.7-fold (0.82 log units) below it; the whole stated range lies below it.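

In this assay, putting 2-chloro-4-fluorophenyl in place of 4-chlorophenyl on a double-bonded chain carbon bound to a double-bonded chain carbon gave a modest step, a 7.7-fold higher number from compound 3 to compound 4 (0.89 log units; beyond the scatter). The earlier compounds shown here showed only that 4-chlorophenyl went with a lower number than phenyl or 4-cyanophenyl; this step shows that a chloro group on the ring does not by itself secure that gain, since compound 4 also carries one and still reads higher than compound 3. The new group also gave a number no higher from compound 1 to compound 4 (the limit leaves the size open) and a number no higher from compound 2 to compound 4 (the limit leaves the size open), so the step to compound 4 from compound 3 is the only size available for the new group: the limit of > 100000 nM in this assay, at which 2 of the 4 values shown sit.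

The step from compound 3 to compound 4 alters the ring in two ways at once, so the compounds shown do not tell whether the added fluoro group or the changed place of the chloro group goes with the higher number. As far as these compounds go, what a 2-chlorophenyl or a 4-fluorophenyl group alone would give at this place stays open, as does the reading of a 4-bromophenyl or a 4-methoxyphenyl group.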